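From cyclobutyl amide to dimethylmorpholine amide

The source may hold more compounds than are shown below. What is called first, only, known or untested is meant among the compounds shown, and "the series" means these compounds.

Compound 1 (`O=C(/C=C/c1ccc(NC(=O)Nc2ccc(Cl)c(C(F)(F)F)c2)cc1)NC1CCC1`): 4530 nM
Compound 2 (`CNC(=O)/C(C)=C/c1ccc(NC(=O)Nc2ccc(Cl)c(C(F)(F)F)c2)cc1`): > 50000 nM (a limit)
Compound 3 (`CNC(=O)c1cccc(-c2ccc(NC(=O)Nc3ccc(Cl)c(C(F)(F)F)c3)cc2)c1`): > 50000 nM (a limit)

In a functional assay on MX1 cells (Homo sapiens) for inhibition, read by MTT assay, with a stated time of 120 h (a lower number here means a stronger inhibitor, a higher number a weaker inhibitor), compound 1 alone has a true number. The other two are held by the limit of > 50000 nM in this assay, at which 2 of the 3 values shown sit, and so carry no number. Compound 4 (`CC1CN(C(=O)/C=C/c2ccc(NC(=O)Nc3ccc(Cl)c(C(F)(F)F)c3)cc2)CC(C)O1`) keeps the core of compound 1 and has 2,6-dimethylmorpholin-4-yl in place of cyclobutylamino on a carbonyl carbon. Both measured steps away from compound 1 alter that same side chain more broadly, one (an at least 11-fold higher number from compound 1 to compound 2 (1.04 log units; beyond the scatter)) and the other (an at least 11-fold higher number from compound 1 to compound 3 (1.04 log units; beyond the scatter)), and both are large. A smaller rise in the same direction is therefore expected (a 3.1-fold higher number from compound 1 to compound 4 (0.49 log units; beyond the scatter)). For compound 4 the expected value is (14000 nM), with 4000 nM to 45000 nM as the estimated range.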

Compound 4, half-maximal inhibitory concentration: 12800 nM
For compound 4 the middle estimate is 1.1-fold (0.04 log units) above the measured one; the measured number falls inside the stated range.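

The change on the carbonyl carbon gives the first step away from compound 1 with a readable size in this assay: a 2.8-fold higher number from compound 1 to compound 4 (0.45 log units; beyond the scatter). The two earlier steps end at a limit instead: the limit of > 50000 nM in this assay, at which 2 of the 4 values shown sit. Compound 4 thus holds a true number with 2,6-dimethylmorpholin-4-yl, which has 0 hydrogen-bond donors, in place of cyclobutylamino, which has 1.

The compounds shown leave open what a morpholine without the two methyl groups, or a piperidine, would give on this carbonyl carbon. They also leave open which part of the entering ring accounts for the step.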